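A few compounds are considered here, and "the series" means these few. Any claim that something is new, unique, unknown or untested is made for them only; others in the source may bear on it.

Working notes on the series. Compound 2 `O=c1cc(-n2cc(COc3ccc(F)cc3)nn2)c2ccccc2o1` gives in a functional assay on SW480 cells (Homo sapiens) for antiproliferative activity, read by MTT assay, with a stated time of 48 h (a lower number here means a stronger inhibitor, a higher number a weaker inhibitor), a value of 3820 nM. Compound 3 `COc1ccc2oc(=O)cc(-n3cc(COc4ccc(F)cc4)nn3)c2c1` gives 25900 nM and stands highest of the two numbers; the step of a 6.8-fold higher number from compound 2 to compound 3 (0.83 log units; beyond the scatter) lies beyond the scatter. Compound 1 `O=c1cc(-n2cc(COc3ccccc3)nn2)c2cc(O)ccc2o1` gives only a limit, > 50000 nM. This matches (the limit of > 50000 nM in this assay, at which 1 of the 3 values shown sits). Compound 4 `O=c1cc(-n2cc(COc3ccc(F)cc3)nn2)c2cc(O)ccc2o1` differs from compound 3 by hydrogen in place of methyl on an oxygen on an aromatic ring. Within the data shown here, no measured step covers this change directly; the step of a 6.8-fold higher number from compound 2 to compound 3 (0.83 log units; beyond the scatter) touches the same oxygen from the other side, and the hydroxy-bearing compound 1 shows no number at all. A weak inhibitor is therefore expected, and compound 4 is estimated at 40000 nM, with a range from 10000 nM to 120000 nM, which means a step of a 1.5-fold higher number from compound 3 to compound 4 (0.19 log units; within the scatter) expected beyond the scatter.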

Compound 4, half-maximal inhibitory concentration: 2720 nM
Estimate against measurement, compound 4: 15-fold (1.17 log units) above; the measured number lies below the stated range.
By their numbers in this assay, from the lowest: compounds 4 and 2 (each within the scatter of the next); then compound 3. At a limit, above all of these: compound 1.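

In this assay, hydrogen in place of methyl on this oxygen gives a 9.5-fold lower number from compound 3 to compound 4 (0.98 log units; beyond the scatter), so the loss seen with methoxy does not carry over to hydroxy. Hydroxy in place of hydrogen gives a 1.4-fold lower number from compound 2 to compound 4 (0.15 log units; within the scatter), which lies within the scatter: among these compounds, this position tolerates hydroxy but not methoxy. With hydroxy held in place, the fluoro step reads an at least 18-fold lower number from compound 1 to compound 4 (1.26 log units; beyond the scatter), and one end of that step is a limit: the limit of > 50000 nM in this assay, at which 1 of the 4 values shown sits.

From the compounds shown here alone, whether an amine or an ethoxy group at this position would follow hydroxy or methoxy stays open. Also open, going by these compounds, is whether fluoro counts for as much without the hydroxy.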